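A few compounds are considered here, and "the series" means these few. Any claim that something is new, unique, unknown or untested is made for them only; others in the source may bear on it.

Measured in an ADME assay (liver) for metabolic stability, with Liver microsome (Homo sapiens) as the target, using microsomes and NADPH, with a stated time of 30 min, tested at 1 uM; on this read-out higher numbers stand for fast clearance and lower numbers for slow clearance:
Compound 1 `Nc1ccc(S(=O)(=O)N2CCN(c3ncc(C(O)(C(F)(F)F)C(F)(F)F)cc3Br)CC2)cn1` gives < 14 mL.min-1.g-1, a limit of the assay rather than a number.
Compound 2 `Nc1ccc(S(=O)(=O)N2CCN(c3ncc(C(O)(C(F)(F)F)C(F)(F)F)cc3C#CCO)CC2)cn1` gives < 14 mL.min-1.g-1, likewise a limit.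
Compound 3 `CC(C)n1cc(-c2cc(C(O)(C(F)(F)F)C(F)(F)F)cnc2N2CCN(S(=O)(=O)c3ccc(N)nc3)CC2)cn1` gives 38 mL.min-1.g-1.

Going by the values given here, compound 3 is thus the only compound with a number in this assay, the other two sitting at the limit of < 14 mL.min-1.g-1 in this assay, at which 2 of the 3 values shown sit. Compound 4 `Nc1ccc(S(=O)(=O)N2CCN(c3ncc(C(O)(C(F)(F)F)C(F)(F)F)cc3-c3ccncc3)CC2)cn1` differs from it by pyridin-4-yl in place of 1-isopropyl-1H-pyrazol-4-yl on an aromatic carbon. Among the compounds with values here, two measured steps bear on this change, both ending at compound 3: an at least 2.7-fold higher number from compound 1 to compound 3 (0.43 log units; beyond the scatter) and an at least 2.7-fold higher number from compound 2 to compound 3 (0.43 log units; beyond the scatter). Both steps that brought in the 1-isopropyl-1H-pyrazol-4-yl raised the number, so removing it in favour of pyridin-4-yl is expected to give a modestly lower number than compound 3. Compound 4 is expected at 22 mL.min-1.g-1, within 10 mL.min-1.g-1 to 45 mL.min-1.g-1. The expected step is a 1.7-fold lower number from compound 3 to compound 4 (0.24 log units; within the scatter).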

Compound 4, intrinsic clearance in microsomes: 15 mL.min-1.g-1
Estimate against measurement, compound 4: 1.5-fold (0.17 log units) above, and the stated range covers the measured number.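

In this assay, pyridin-4-yl in place of 1-isopropyl-1H-pyrazol-4-yl on an aromatic carbon gives a 2.5-fold lower number from compound 3 to compound 4 (0.40 log units; beyond the scatter) as a modest step. This shows that the read-out at this aromatic carbon depends on which aromatic ring stands there, not merely on an aromatic ring being present. Pyridin-4-yl in place of 3-hydroxyprop-1-yn-1-yl gives an at least 1.0-fold higher number from compound 2 to compound 4 (0.02 log units; that floor lies within the scatter) and pyridin-4-yl in place of bromo gives an at least 1.0-fold higher number from compound 1 to compound 4 (0.02 log units; that floor lies within the scatter) as floors only. Compound 1 and compound 2 each give only a limit: the limit of < 14 mL.min-1.g-1 in this assay, at which 2 of the 4 values shown sit.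

As far as these compounds go, it remains open whether the isopropyl group or the pyrazole ring itself carries the higher number of compound 3. Also open, from the compounds shown here alone, is how a methyl group in place of the isopropyl, or an amine on this carbon, would read.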